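The compounds below may be only part of what the source reports. "The series", "measured", "known", "first", "only" and "open" are said of these compounds alone.

Measured compounds in the series:

compound 1 `O=C(CCc1ccc(F)cc1)NNc1c(Cl)cncc1Cl` — 900 nM in a functional assay on HEK293 cells for antagonist activity at P2X purinoceptor 7 (Homo sapiens), read by fluorescence, with a stated time of 2 h; on this read-out lower numbers stand for stronger inhibition and higher numbers for weaker inhibition
compound 2 `O=C(CCCc1ccccc1)NNc1c(Cl)cncc1Cl` — 770 nM
compound 3 `O=C(NNc1c(Cl)cncc1Cl)OCc1ccccc1` — 370 nM

Compound 2 stands second highest of the three numbers. Its nearest neighbour is compound 1, and the step of a 1.2-fold lower number from compound 1 to compound 2 (0.07 log units; within the scatter) is within the scatter. Its furthest is compound 3, whose number is lower by a margin that lies beyond the scatter; no single-point difference is defined for that pair, so only the two values themselves can be set side by side.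

Compound 4 `O=C(CCCC1CCCCC1)NNc1c(Cl)cncc1Cl` differs from compound 2 by cyclohexyl in place of phenyl on a saturated chain carbon, three bonds along the chain from a carbonyl carbon. Within the data shown here, of the measured steps, only the one from compound 1 to compound 2 concerns the same chain carbon, and that step was within the scatter; no measured step exchanges an aromatic ring for a non-aromatic one, so nothing in the set speaks directly to this exchange. The nearest analogy, a change at the chain terminus leaving the shared core untouched, produced no movement beyond the scatter. The expectation for this assay is therefore a step of modest size and uncertain direction: compound 4 is expected to give 800 nM, within 300 nM to 2500 nM. The implied step from compound 2 is estimated as a 1.0-fold higher number from compound 2 to compound 4 (0.02 log units; within the scatter).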

Compound 4, half-maximal inhibitory concentration: 360 nM
Estimate against measurement, compound 4: 2.2-fold (0.35 log units) above; the range from low to high includes it.
By their numbers in this assay, from the lowest: compounds 4 and 3 (each within the scatter of the next); then compounds 2 and 1 (each within the scatter of the next).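

In this assay, cyclohexyl in place of phenyl on a saturated chain carbon, three bonds along the chain from a carbonyl carbon, gives a 2.1-fold lower number from compound 2 to compound 4 (0.33 log units; beyond the scatter) and so moves the number beyond the scatter, which the earlier change at this chain end, a 1.2-fold lower number from compound 1 to compound 2 (0.07 log units; within the scatter), did not do. Cyclohexylmethyl in place of 4-fluorophenyl gives a 2.5-fold lower number from compound 1 to compound 4 (0.40 log units; beyond the scatter) and points the same way, so among these compounds the chain end needs no aromatic ring to hold this level of inhibition, and the non-aromatic ring gives the lower number in both comparisons. Nothing measured in the set accounts for these steps.

Still open, on these data alone, is whether the cyclohexyl result holds on a shorter or a longer chain, and whether a cyclopentyl or a tert-butyl group at the same chain carbon would serve as well as the six-membered ring. Also open, as far as these compounds go, is whether a piperidine ring, which brings in an amine, or a hydroxyl group on the cyclohexyl ring would be accepted there.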